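The compounds below may be only part of what the source reports. "The series", "measured", "known", "first", "only" and "open" are said of these compounds alone.

Working notes on the series, step from compound 2 to compound 3.

Compound 1 `COc1ccc(-c2cnc(NC(=O)c3cccc(Br)c3)n2C)cc1` and compound 2 `COc1ccc(-c2cnc(NC(=O)c3ccc(Br)cc3)n2C)cc1` share one core; compound 3 `COc1ccc(-c2cnc(NC(=O)c3ccncc3)n2C)cc1` is the next member and has not been measured. In a toxicity assay on THP-1 cells (Homo sapiens) for inhibition (on this read-out lower numbers stand for higher toxicity in this test and higher numbers for lower toxicity in this test), compound 1 gives only a limit of the assay, > 100000 nM. In this assay compound 2 likewise gives only a limit of the assay, > 100000 nM. The step that the two limits leave unreadable from compound 1 to compound 2 is consequently of unknown size and direction. On the numbers shown, compound 2 stands at the limit, and the one further value sits there as well, so that both rest on (the limit of > 100000 nM in this assay, at which 2 of the 2 values shown sit).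

The change toward compound 3 is pyridin-4-yl in place of 4-bromophenyl on a carbonyl carbon. Going by the values given here, the only measured step that touches the same carbonyl carbon, a step that the two limits leave unreadable from compound 1 to compound 2, offers no size to carry over, and no measured step involves a pyridin-4-yl at all. What the two values do show is that neither bromophenyl amide reaches a readable toxicity in this assay.

Compound 3 is expected to give 100000 nM in this assay, with a range from 40000 nM to 300000 nM. The expected step is a number no higher from compound 2 to compound 3 (the limit leaves the size open), most probably again only a limit.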

Compound 3, half-maximal cytotoxic concentration: > 100000 nM
Compound 3: a limit, no number; the forecaster's own chance of this, stated with the estimate: 80%; the middle value sits exactly at the limit.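

Compound 3, like compound 1 and compound 2, gives only a limit of the assay in this assay, so no step among the three can be read: the limit of > 100000 nM in this assay, at which 3 of the 3 values shown sit.

The compounds shown leave open how the 3-bromophenyl, 4-bromophenyl and pyridin-4-yl amides rank against one another in this assay, and whether any change on the carbonyl carbon yields a readable value.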